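The compounds below may be only part of what the source reports. "The series", "measured", "known", "first", "only" and "open" are said of these compounds alone.

Measured in an ADME assay on DU-145 cells (Homo sapiens) for cytotoxicity, read by MTT assay, with a stated time of 72 h; on this read-out higher numbers stand for weaker inhibition and lower numbers for stronger inhibition:
Compound 1 `COc1ccc(C2=C(c3cc(OC)c(OC)c(OC)c3)CC(O)C2=O)cc1[N+](=O)[O-]`: > 100 ug/mL (a limit)
Compound 2 `COc1ccc(C2=C(c3cc(OC)c(OC)c(OC)c3)CC(O[SiH2]C(C)(C)C)C2=O)cc1[N+](=O)[O-]`: > 100 ug/mL (a limit)

Compound 1 stands at > 100 ug/mL, which is a limit of this assay and not a number. Compound 3 `COc1ccc(C2=C(c3cc(OC)c(OC)c(OC)c3)CC(O)C2=O)cc1N` differs from compound 1 by one change: amino in place of nitro on an aromatic carbon. The only measured step, a step that the two limits leave unreadable from compound 1 to compound 2, lies on an oxygen on a saturated carbon, so it sets no size here, and the limit of > 100 ug/mL in this assay, at which 2 of the 2 values shown sit, is all that is shown. Any readable number would mean stronger inhibition, so a step in that direction, of uncertain size, is expected: an at least 2.0-fold lower number from compound 1 to compound 3 (0.30 log units; that floor lies within the scatter). Compound 3 is estimated at 50 ug/mL, with an expected range of 5 ug/mL to 150 ug/mL.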

Compound 3, half-maximal inhibitory concentration: 41 ug/mL
Compound 3: the middle estimate sits 1.2-fold (0.09 log units) above what was measured; the range from low to high includes it.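

Amino in place of nitro on this aromatic carbon, ortho to a methoxy group, gives an at least 2.4-fold lower number from compound 1 to compound 3 (0.38 log units; beyond the scatter) in this assay. This position therefore yields a readable number, whereas the earlier step, on an oxygen on a saturated carbon, could not be read. The true size of the new step stays open, since compound 1 carries a limit and not a number: the limit of > 100 ug/mL in this assay, at which 2 of the 3 values shown sit.

The compounds shown leave open how a hydroxyl, an acetamide or a dimethylamino group would read on this same aromatic carbon. They also leave open whether the amino compound would keep a readable number with the oxygen capped as in compound 2.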